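Swapping a pyrrolidine for a dichloroaniline on the amide tail

The compounds below may be only part of what the source reports. "The series", "measured", "known", "first", "only" and "open" are said of these compounds alone.

The measured compounds, all tested in an ADME assay on J774 cells (Mus musculus) for cytotoxicity, read by MTT assay, with a stated time of 48 h; on this read-out higher numbers stand for weaker inhibition and lower numbers for stronger inhibition:
Compound 1, `CC(C)(C)OC(=O)NCCCCNc1cc(/C=C/c2ccccc2)nc2ccccc12`, gives 3700 nM.
Compound 2, `NCCNc1cc(/C=C/c2ccccc2)nc2ccccc12`, gives 4600 nM.
Compound 3, `O=C(CN1CCCC1)NCCNc1cc(/C=C/c2ccccc2)nc2ccccc12`, gives 12500 nM.

Compound 3 carries the highest number of the three; its steps to the others, a 2.7-fold higher number from compound 2 to compound 3 (0.43 log units; beyond the scatter) and a 3.4-fold higher number from compound 1 to compound 3 (0.53 log units; beyond the scatter), both lie beyond the scatter, so it is the weakest inhibitor here. Compound 4, `O=C(CNc1ccc(Cl)cc1Cl)NCCNc1cc(/C=C/c2ccccc2)nc2ccccc12`, keeps the whole core and amide tail of compound 3 and changes only the end of that tail: (2,4-dichlorophenyl)amino in place of pyrrolidin-1-yl on a saturated chain carbon bound to a carbonyl carbon.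

Among the measured compounds shown here, no measured step shows this particular swap. The steps that touch the same region, a 3.4-fold higher number from compound 1 to compound 3 (0.53 log units; beyond the scatter) and a 2.7-fold higher number from compound 2 to compound 3 (0.43 log units; beyond the scatter), were both modest, and a 1.2-fold higher number from compound 1 to compound 2 (0.09 log units; within the scatter) stayed within the scatter. On that basis only a modest shift is expected, a 1.8-fold lower number from compound 3 to compound 4 (0.25 log units; within the scatter), with the direction uncertain. Compound 4 is therefore estimated at 7000 nM in this assay, within a range from 2500 nM to 20000 nM.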

Compound 4, half-maximal inhibitory concentration: > 50000 nM
Compound 4 was reported as a limit; the forecaster's own chance of this, stated with the estimate: 10%; middle value at least 7.1-fold (0.85 log units) away from the limit.
By their numbers in this assay, from the lowest: compounds 1 and 2 (each within the scatter of the next); then compound 3. At a limit, above all of these: compound 4.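

The end of the amide tail can shift this read-out on its own: in this assay, (2,4-dichlorophenyl)amino in place of pyrrolidin-1-yl on a saturated chain carbon bound to a carbonyl carbon gives an at least 4.0-fold higher number from compound 3 to compound 4 (0.60 log units; beyond the scatter), which means weaker inhibition. For compound 4, the value > 50000 nM is a limit and not a number: the limit of > 50000 nM in this assay, at which 1 of the 4 values shown sits. This one swap brings in an aromatic ring of carbon only, chlorine atoms and a hydrogen-bond donor together, so it cannot show which of these parts goes with the change.

A plain phenylamino group without chlorine, tested at the same place, would help separate the ring from the chlorine atoms. A piperidine or morpholine there would show how other saturated rings compare with pyrrolidin-1-yl.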